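The source may report more compounds than this note shows. Statements on the series, on what has been measured and on what is new or still open speak of the compounds shown alone.

In a functional assay on CWR22R cells (Homo sapiens) for antiproliferative activity, read by propidium iodide staining, with a stated time of 96 h (on this read-out higher numbers stand for weaker inhibition and lower numbers for stronger inhibition), three compounds have been measured:

compound 1, `CC(O)(CSc1cccc(C(F)(F)F)c1)C(=O)Nc1cccc(S(F)(F)(F)(F)F)c1`: 12900 nM
compound 2, `CC(O)(CSc1cccc(OC(F)(F)F)c1)C(=O)Nc1cccc(S(F)(F)(F)(F)F)c1`: 18700 nM
compound 3, `CC(O)(COc1ccc(C(F)(F)F)cc1)C(=O)Nc1cccc(S(F)(F)(F)(F)F)c1`: 3600 nM

Compound 3 gives the lowest number of the three, and its gaps to compound 1 and to compound 2 are both beyond the usual scatter of repeated measurements. Compound 4, `CC(O)(COc1ccc(OC(F)(F)F)cc1)C(=O)Nc1cccc(S(F)(F)(F)(F)F)c1`, has not yet been measured.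

Compound 4 differs from compound 3 in one place: trifluoromethoxy in place of trifluoromethyl on an aromatic carbon. The same kind of change already links two measured compounds, compound 1 and compound 2: trifluoromethoxy in place of trifluoromethyl on an aromatic carbon. The two changes are not identical, since in compound 2 the new group sits meta to a large group while in compound 4 it sits para to a large group; they are the same kind of change on different cores. How the core of compound 1 differs from the core of compound 3 is not broken down here. The measured change gave a 1.4-fold higher number from compound 1 to compound 2 (0.16 log units; within the scatter), a step within the scatter.

Resting on that one step, the change from compound 3 to compound 4 is expected to be small as well, about a 1.3-fold higher number from compound 3 to compound 4 (0.10 log units; within the scatter). On that basis compound 4 is estimated to give about 4500 nM in this assay, with a likely range from 1800 nM to 11000 nM. Among the measured compounds shown here, only one earlier example of the change exists, so the expectation is loose.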

Compound 4, half-maximal inhibitory concentration: 12900 nM
Compound 4: the middle estimate sits 2.9-fold (0.46 log units) below what was measured, and the stated range ends below it.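

In this assay, putting trifluoromethoxy in place of trifluoromethyl on an aromatic carbon gave a 3.6-fold higher number from compound 3 to compound 4 (0.55 log units; beyond the scatter) on this core. This step lies beyond the usual scatter of repeated measurements, whereas the earlier example of the change, on the core of compound 1, lies within it. Even so, the two steps cannot be told apart, so nothing here shows that the core alters the effect of the change, although two examples are also too few to prove that the change carries over unchanged to other cores: the same change on two cores in this assay, a 1.4-fold higher number (0.16 log units; within the scatter) from compound 1 to compound 2 and a 3.6-fold higher number (0.55 log units; beyond the scatter) from compound 3 to compound 4, 2.5-fold (0.39 log units) apart, within the scatter of two such steps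

The compounds shown have only trifluoromethyl or trifluoromethoxy on this aromatic ring, so it remains open how a smaller group such as a chlorine atom, a methyl group or a nitrile would compare with them on either core. All four compounds also share the same amide portion, which leaves open how the numbers would respond if an amine or a carboxylic acid were attached to that part of the molecule.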